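Urea to Amide at the Aniline of Compound 2

The source may hold more compounds than are shown below. What is called first, only, known or untested is meant among the compounds shown, and "the series" means these compounds.

Measured in a functional assay on TK-10 cells (Homo sapiens) for inhibition, read by sulforhodamine B assay, with a stated time of 48 h; on this read-out higher numbers stand for weaker inhibition of growth and lower numbers for stronger inhibition of growth:
compound 1 `COc1cc(-c2nn(-c3cccc(NC(=O)Nc4cc(C(F)(F)F)cc(C(F)(F)F)c4)c3)cc2-c2ccncc2)ccc1Cl` gives 2480 nM
compound 2 `COc1cc(-c2nn(-c3cccc(NC(=O)Nc4ccc(Cl)c(Cl)c4)c3)cc2-c2ccncc2)ccc1Cl` gives 40900 nM
compound 3 `O=C(Nc1cccc(-n2cc(-c3ccncc3)c(-c3ccc(Cl)c(O)c3)n2)c1)Nc1ccc(Cl)c(Cl)c1` gives only a limit, > 32500 nM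

Compound 2 holds the higher of the two numbers shown; compound 1 holds the lower, and the gap between them lies beyond the scatter. The step that the limit leaves unreadable from compound 2 to compound 3 cannot be read because compound 3 sits at the limit of > 32500 nM in this assay, at which 1 of the 3 values shown sits. Compound 4 `COc1cc(-c2nn(-c3cccc(NC(=O)c4ccccc4)c3)cc2-c2ccncc2)ccc1Cl` differs from compound 2 by phenyl in place of (3,4-dichlorophenyl)amino on a carbonyl carbon. Among the compounds with values here, no measured step touches this position, so the expectation rests on compound 2 alone and is taken to stay close to it; it is estimated that the step of a 1.1-fold higher number from compound 2 to compound 4 (0.04 log units; within the scatter) stays within the scatter. Compound 4 is therefore expected to give about 45000 nM in this assay, within 15000 nM to 150000 nM.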

Compound 4, concentration for total growth inhibition: > 100000 nM
Compound 4: only a limit was reported; the forecaster's own chance of this, stated with the estimate: 35%; at least 2.2-fold (0.34 log units) between middle value and limit.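

Moving from the (3,4-dichlorophenyl)amino group to phenyl on the carbonyl carbon, the urea becomes a benzamido group, and this is read as an at least 2.4-fold higher number from compound 2 to compound 4 (0.38 log units; beyond the scatter). In this assay compound 4 gives > 100000 nM, which is a limit and not a number. Within the data shown here, this is the first reading at this position, and it shows that the change weakens growth inhibition rather than leaving it unchanged.

The change removes the amino nitrogen and both chlorine atoms together, so the compounds shown leave open which of these accounts for the step. A dichlorobenzoyl group on the same nitrogen would keep the chlorine atoms without the amino nitrogen.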